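This account rests on a few compounds, and the source may have more. Where it says the series, first, only, none or still open, it means among the compounds named here.

Measured so far:
compound 1 `COc1ccc(-c2cc(/C=C/C(=O)c3ccc(N)cc3)[nH]n2)cc1` — in a functional assay on PC-3 cells (Homo sapiens) for cytotoxicity, read by sulforhodamine B assay, with a stated time of 48 h, tested at 0.1 uM (a lower number here means a stronger effect, a higher number a weaker effect of the compound at the concentration tested), compound 1 gives 93%;
compound 2 `COc1ccc(-c2cc(/C=C/C(=O)c3ccc(N)cc3)[nH]n2)cc1OC` — in this assay compound 2 gives 95%;
compound 3 `COc1cc(C(=O)/C=C/c2cc(-c3cc(OC)c(OC)c(OC)c3)n[nH]2)cc(OC)c1OC` — in this assay compound 3 gives 92%.

The three numbers sit close together. Compound 2 and compound 1 differ by a single change, (hydrogen in place of methoxy on an aromatic carbon), and the step that accompanies it is a number 2 percentage points lower from compound 2 to compound 1 (within the scatter). Compound 3 shares much with compound 2, but how the two cores differ is not broken down here; their two values are within the scatter of each other.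

Compound 4 `COc1ccc(-c2cc(/C=C/C(=O)c3cc(OC)c(OC)c(OC)c3)[nH]n2)cc1OC` is not yet measured. It is made from compound 3 by hydrogen in place of methoxy on an aromatic carbon. Among the compounds with values here, this is the same kind of change as the one from compound 2 to compound 1, not the same: around the place in compound 3 the carbon is also meta to a methoxy group (2 heavy atoms), which the place in compound 2 is not.

For compound 4 the expected step is no change at the digits printed from compound 3 to compound 4 (within the scatter), a step within the scatter, because the matching step a number 2 percentage points lower from compound 2 to compound 1 (within the scatter) was itself within the scatter. The estimate for compound 4 in this assay is therefore 92%, with a range from 84% to 100%.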

Compound 4, a percentage reported as activity, at one concentration (the size of the read-out at that concentration, not a potency): 93%
Compound 4: middle estimate off by 1 percentage points, on the low side; measured number inside the range.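

Replacing one methoxy group with hydrogen on the core of compound 3 gives, in this assay, a number 1 percentage points higher from compound 3 to compound 4 (within the scatter). Set beside the same change on the other core, the two steps do not differ: the same change on two cores in this assay, a number 2 percentage points lower (within the scatter) from compound 2 to compound 1 and a number 1 percentage points higher (within the scatter) from compound 3 to compound 4, 3 percentage points apart, within the scatter of two such steps

So far, then, this change can be carried from one core to the other without a step beyond the scatter appearing on either. This does not show that the change has no effect, or that the two cores truly respond alike, as neither step is large enough to be told from the scatter, and the read-out comes from a single concentration.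

The compounds shown leave open whether a group other than methoxy or hydrogen at this place, such as a hydroxyl group, a fluorine atom or a carboxylic acid, would give a step beyond the scatter. They also leave open how the same change would behave on a core outside these two.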